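The source may report more compounds than this note shows. Statements on the series, on what has been measured and on what is new or still open speak of the compounds shown alone.

Measured compounds:
compound 1 `O=[N+]([O-])c1ccc(/C=N/Cc2cccnc2)cc1` — 100 mg/kg
compound 2 `Clc1ccccc1/C=N/Cc1cccnc1` — 100 mg/kg
compound 3 `C(=N/Cc1cccnc1)\c1ccccc1` — 100 mg/kg

All three were run in a functional assay on the whole organism (strain Swiss albino) with Mus musculus as the target, with a stated time of 4 h; a higher number here means that more compound is needed for the effect, a lower number that less compound is needed. Compound 3 stands level with compound 1 and compound 2 at the digits recorded: the nearest to it is compound 1, the furthest compound 2, and neither gap is beyond the scatter. The two steps that lead to compound 3 are no change at the digits printed from compound 1 to compound 3 (within the scatter) and no change at the digits printed from compound 2 to compound 3 (within the scatter); both remove a substituent from the aromatic ring and leave the read-out flat.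

Compound 4 `Clc1ccc(/C=N/Cc2cccnc2)cc1` has not yet been measured. Its change from compound 3 is chloro in place of hydrogen on an aromatic carbon. This is the reverse of the kind of step seen twice already, and in both of those cases the read-out did not move beyond the scatter. For the measured compounds named here, no measured step supports a change in either direction. The expected step is therefore no change at the digits printed from compound 3 to compound 4 (within the scatter), with compound 4 estimated at 100 mg/kg and a range of 50 mg/kg to 200 mg/kg.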

Compound 4, minimum effective dose: 300 mg/kg
Compound 4: the middle estimate sits 3.0-fold (0.48 log units) below what was measured; the whole stated range lies below it.
By their numbers in this assay, from the lowest: compounds 1, 2 and 3 (each within the scatter of the next); then compound 4.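

In this assay, for the compounds shown here, chloro para to the group of 9 heavy atoms is the first ring substituent to move the read-out, with a 3.0-fold higher number from compound 3 to compound 4 (0.48 log units; beyond the scatter). At the same place, the exchange of nitro for chloro gives a 3.0-fold higher number from compound 1 to compound 4 (0.48 log units; beyond the scatter), whereas the removal of nitro gives no change at the digits printed from compound 1 to compound 3 (within the scatter), so the result at this position depends on the group and not merely on the presence of a substituent. A chloro group alone does not set the higher number: compound 2 also carries one and gives 100 mg/kg, while compound 4 gives 300 mg/kg.

As far as these compounds go, whether bromo, methyl, methoxy or an amine at this place would follow chloro or stay level with hydrogen and nitro remains open. No measurement at hand accounts for the shift.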